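The source may report more compounds than this note shows. Statements on the series, on what has been measured and on what is new or still open speak of the compounds shown alone.

Of the compounds shown here, three have so far been measured in an assay for inhibition of protein disulfide-isomerase (Homo sapiens), with a stated time of 1 h; a higher number here means a weaker inhibitor, a lower number a stronger inhibitor. Compound 1 `Oc1ccc2[nH]ncc2c1C(c1ccc(-n2cccc2)cc1)N1CCCCC1` gives 290 nM and stands highest of the two plain numbers in hand. Compound 2 `Cc1ccnc(NC(c2ccc(F)cc2)c2ccc3cccnc3c2O)c1` gives 140 nM, a number whose distance from that of compound 1 lies beyond the usual scatter of repeated measurements. For compound 3 `Oc1ccc2ncccc2c1C(c1ccc(F)cc1)N1CCCCC1` the result is not a number but a limit, recorded as > 30000 nM, which matches (the limit of > 30000 nM in this assay, at which 1 of the 3 values shown sits).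

Compound 4 `Oc1ccc2[nH]ncc2c1C(c1ccc(-c2nccs2)cc1)N1CCCCC1` has not yet been measured in this assay. It differs from compound 1 in one place: 1,3-thiazol-2-yl in place of 1H-pyrrol-1-yl on an aromatic carbon, the incoming ring sitting para to a large group. Within the data shown here, no step between measured compounds bears on this exchange, so neither its direction nor its size can be read from the data in hand. The expectation is therefore a step no larger than the scatter, estimated as a 1.0-fold higher number from compound 1 to compound 4 (0.01 log units; within the scatter). In this assay compound 4 is expected to give about 300 nM, with a range from 100 nM to 1000 nM.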

Compound 4, half-maximal inhibitory concentration: 340 nM
The estimate for compound 4 lay 1.1-fold (0.05 log units) below the measured number, and the stated range covers the measured number.
By their numbers in this assay, from the lowest: compound 2; then compounds 1 and 4 (each within the scatter of the next). At a limit, above all of these: compound 3.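

In this assay, among these compounds, the exchange of 1H-pyrrol-1-yl for 1,3-thiazol-2-yl on an aromatic carbon, para to a large group, gives a 1.2-fold higher number from compound 1 to compound 4 (0.07 log units; within the scatter) and provides the first reading of any change at this position. A five-membered aromatic ring with 1 hetero atom and one with 2 hetero atoms, the latter bringing in sulfur, therefore give numbers within the scatter of each other on the core of compound 1. Nothing measured here bears on why the two rings read alike.

As far as these compounds go, it remains open whether a group of another kind at this position, such as an amine, a carboxylic acid or a longer alkyl chain, would leave the number within the scatter as well. This single pair also leaves open whether the same exchange would read alike on any other core.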